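The source may hold more compounds than are shown below. What is called first, only, known or untested is meant among the compounds shown, and "the series" means these compounds.

Three long-chain compounds sharing two neighbouring triple bonds and a hydroxyl group have been tested in a functional assay on XF498 cells (Homo sapiens) for cytotoxicity; on this read-out lower numbers stand for an effect already at smaller amounts and higher numbers for an effect only at larger amounts of compound. Compound 1, `C=CCCCCCCCC#CC#CC(O)CC(C)=O`, gives 4.45 ug/mL in this assay. Compound 2, `C=CCCCCCCCC#CC#CCO`, gives 5.26 ug/mL in this assay, and compound 3, `CCCCCCCC#CC#CCO`, gives 5.59 ug/mL in this assay. Compound 2 and compound 1 differ by 2-oxopropyl in place of hydrogen on a saturated chain carbon bound to an oxygen on a saturated carbon and a triple-bonded carbon, and this change made a 1.2-fold lower number from compound 2 to compound 1 (0.07 log units; within the scatter). The cores of compound 2 and compound 3 differ by hydrogen in place of vinyl on a saturated chain carbon, seven bonds along the chain from a triple-bonded carbon, a change that made a 1.1-fold higher number from compound 2 to compound 3 (0.03 log units; within the scatter).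

Compound 4, `CCCCCCCC#CC#CC(O)CC(C)=O`, has not yet been measured. It differs from compound 3 by 2-oxopropyl in place of hydrogen on a saturated chain carbon bound to an oxygen on a saturated carbon and a triple-bonded carbon. Among the compounds with values here, this is the same change as the one from compound 2 to compound 1, at the same place word for word. Since that earlier change gave a 1.2-fold lower number from compound 2 to compound 1 (0.07 log units; within the scatter), the step from compound 3 to compound 4 is expected to be roughly a 1.2-fold lower number from compound 3 to compound 4 (0.07 log units; within the scatter), again within the usual scatter. On that basis compound 4 is expected to give about 4.8 ug/mL in this assay, with a plausible range from 2.8 ug/mL to 8.5 ug/mL.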

Compound 4, concentration for half-maximal effect: 3.7 ug/mL
Compound 4: middle estimate off by 1.3-fold (0.11 log units), on the high side; measured number inside the range.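

In this assay, placing 2-oxopropyl on the core of compound 3 gave a 1.5-fold lower number from compound 3 to compound 4 (0.18 log units; within the scatter), and this agrees with the same change on the vinyl-bearing core: the same change on two cores in this assay, a 1.2-fold lower number (0.07 log units; within the scatter) from compound 2 to compound 1 and a 1.5-fold lower number (0.18 log units; within the scatter) from compound 3 to compound 4, 1.3-fold (0.11 log units) apart, within the scatter of two such steps. Replacing vinyl with hydrogen on the core of compound 1 gave a 1.2-fold lower number from compound 1 to compound 4 (0.08 log units; within the scatter), and this too agrees with the earlier step: the same change on two cores in this assay, a 1.1-fold higher number (0.03 log units; within the scatter) from compound 2 to compound 3 and a 1.2-fold lower number (0.08 log units; within the scatter) from compound 1 to compound 4, 1.3-fold (0.11 log units) apart, within the scatter of two such steps. Each change therefore carried over between these two cores with no difference that can be told from the scatter, but each step is itself within the scatter, so the data do not show that either change truly moves the number, and two cores are too few to establish a general rule for the series.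

From the compounds shown here alone, it remains open whether an amine or a carboxylic acid in place of 2-oxopropyl, on the same saturated chain carbon, would produce a step beyond the scatter. A longer chain in place of the vinyl-bearing end is equally untested by the compounds shown here.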